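Aryl ketone variation on the pyrazole chalcone series

The source may report more compounds than this note shows. Statements on the series, on what has been measured and on what is new or still open speak of the compounds shown alone.

Measured so far:
compound 1 `COc1cc(-c2cc(/C=C/C(=O)c3ccc(N)cc3)[nH]n2)cc(OC)c1OC` — 82%
compound 2 `COc1ccc(C(=O)/C=C/c2cc(-c3cc(OC)c(OC)c(OC)c3)n[nH]2)cc1OC` — 70%

Among the compounds with values here, in a functional assay on SW-620 cells (Homo sapiens) for cytotoxicity, read by sulforhodamine B assay, with a stated time of 48 h, tested at 1 uM (a lower number here means a stronger effect, a higher number a weaker effect of the compound at the concentration tested), compound 2 gives the lowest of the two numbers; the nearest is compound 1, and the change a number 12 percentage points lower from compound 1 to compound 2 (beyond the scatter) is the only step known at the carbonyl carbon. Compound 3 `COc1cc(-c2cc(/C=C/C(=O)c3ccc(F)c(F)c3)[nH]n2)cc(OC)c1OC` has not yet been tested. It differs from compound 2 by 3,4-difluorophenyl in place of 3,4-dimethoxyphenyl on a carbonyl carbon. Within the data shown here, no measured step swaps one substituted phenyl for another of this kind at the carbonyl carbon, so the only guide is that the single known exchange there moved the read-out modestly. A step of similar or smaller size is therefore expected in this assay, in either direction, and one lying within the usual scatter would not be surprising. Compound 3 is estimated at 75%, with a range from 55% to 95%. Among the measured compounds shown here, the expected step of a number 5 percentage points higher from compound 2 to compound 3 (within the scatter) is taken to be small, leaning slightly toward a weaker effect because the only reference step a number 12 percentage points lower from compound 1 to compound 2 (beyond the scatter) was itself modest.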

Compound 3, a percentage reported as activity, at one concentration (the size of the read-out at that concentration, not a potency): 93%
Compound 3: the middle estimate sits 18 percentage points below what was measured, and the stated range covers the measured number.
By their numbers in this assay, from the lowest: compound 2; then compound 1; then compound 3.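

In this assay, the exchange of 3,4-dimethoxyphenyl for 3,4-difluorophenyl on the carbonyl carbon gives a number 23 percentage points higher from compound 2 to compound 3 (beyond the scatter), so this position responds beyond the scatter not only to the replacement of 4-aminophenyl but also to a change of the two substituents on the phenyl ring. The replacement of 4-aminophenyl by 3,4-difluorophenyl gives a number 11 percentage points higher from compound 1 to compound 3 (beyond the scatter), which makes compound 3 the weakest of the three in this assay and shows that read-outs at this position can move in both directions from compound 1, with 3,4-dimethoxyphenyl on the stronger side and 3,4-difluorophenyl on the weaker. The 2 hydrogen-bond acceptors of the leaving group and the 0 of the entering group are counted differences only, and no measurement at hand accounts for the shift.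

Still open, going by these compounds, is how a phenyl carrying a single fluorine or a single methoxy group would read at this carbonyl carbon, which would separate the effect of one substituent from that of the pair. Also open, on these data alone, is whether a carboxylic acid or a dimethylamino group on the phenyl ring would fall with 3,4-dimethoxyphenyl or with 3,4-difluorophenyl.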